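The source may report more compounds than this note shows. Statements on the series, on what has been measured and on what is new or still open speak of the compounds shown alone.

Measured compounds in a functional assay on HeLa cells (Homo sapiens) for cytotoxicity, read by cell counting, with a stated time of 48 h; on this read-out lower numbers stand for an effect already at smaller amounts and higher numbers for an effect only at larger amounts of compound:
- compound 1, `CCCCCCCCCC(=O)O[C@H]1[C@H](O)[C@H](n2ccc(N)nc2=O)O[C@@H]1CO`: 0.09 ug/mL
- compound 2, `CCCCCCC/C=C\C(=O)O[C@H]1[C@H](O)[C@H](n2ccc(N)nc2=O)O[C@@H]1CO`: 0.06 ug/mL
- compound 3, `CCCC(=O)O[C@H]1[C@H](O)[C@H](n2ccc(N)nc2=O)O[C@@H]1CO`: 0.11 ug/mL

Compound 1 sits second highest of these three numbers, and all three lie within the usual scatter of one another: the step of a 1.5-fold lower number from compound 1 to compound 2 (0.18 log units; within the scatter) and the step of a 1.2-fold higher number from compound 1 to compound 3 (0.09 log units; within the scatter) are both within the scatter, as is the step of a 1.8-fold higher number from compound 2 to compound 3 (0.26 log units; within the scatter). The three compounds share the same core and differ only in the ester chain on the carbonyl carbon; the step from compound 1 to compound 3 removes hexyl from a saturated chain carbon, three bonds along the chain from a carbonyl carbon, and the number barely moves.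

Compound 4, `CCCCCCCCCCCCCCCCCCCCCC(=O)O[C@H]1[C@H](O)[C@H](n2ccc(N)nc2=O)O[C@@H]1CO`, extends the chain in the other direction: dodecyl in place of hydrogen on a saturated chain carbon, nine bonds along the chain from a carbonyl carbon. Among the measured compounds shown here, the steps that bear on this are those in which the chain was shortened or altered without the cytotoxicity number moving beyond the scatter. A much longer chain has not been tested, so the extrapolation is uncertain, but the shown steps give no reason to expect a shift in this assay beyond the scatter, in either direction. The estimated step of a 1.3-fold higher number from compound 1 to compound 4 (0.12 log units; within the scatter) is therefore expected to be small. Compound 4 is estimated at 0.12 ug/mL, with a range from 0.04 ug/mL to 0.45 ug/mL.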

Compound 4, concentration for half-maximal effect: 1.1 ug/mL
Beside the measured number, compound 4's estimate is 9.2-fold (0.96 log units) below it; measured number outside the range, above it.
By their numbers in this assay, from the lowest: compounds 2, 1 and 3 (each within the scatter of the next); then compound 4.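

In this assay, among the compounds shown here, putting dodecyl in place of hydrogen on a saturated chain carbon, nine bonds along the chain from a carbonyl carbon, gives a 12-fold higher number from compound 1 to compound 4 (1.09 log units; beyond the scatter), the first step to lie beyond the scatter, so more of compound 4 is needed for the same effect. The earlier steps shown here could not show this: taking hexyl away gave only a 1.2-fold higher number from compound 1 to compound 3 (0.09 log units; within the scatter), so the ester chain tolerates shortening here, but the same tolerance does not hold for this much longer chain, and the response to chain length is one-sided across these compounds. No measurement shown here explains why the longer chain raises the number.

On these data alone, what remains open is where between hydrogen and dodecyl on this carbon the number starts to climb, which a butyl or hexyl group in that place would help to locate. As far as these compounds go, it is also open whether the rise depends on chain length alone, a question that dodecyl chains carrying an amine or a carboxylic acid could test.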